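The source may report more compounds than this note shows. Statements on the series, on what has been measured and on what is new or still open speak of the compounds shown alone.

In an ADME assay on HepG2 cells (Homo sapiens) for cytotoxicity, read by luminescence, CellTiter-Glo and ATP content, with a stated time of 72 h (a lower number here means that less compound is needed, a higher number that more compound is needed for the effect), compound 3 (`COc1cccc(CNCCCNc2ccnc3cc(-c4ccc(C(C)(C)C)cc4)ccc23)c1O`) gives 690 nM, the lowest of the three numbers available. Compound 1 (`COc1ccc(-c2ccc3c(NCCCNCc4cccc(OC)c4O)ccnc3c2)cc1`) gives 1600 nM and compound 2 (`FC(F)(F)c1ccc(-c2ccc3c(NCCCNCc4ccco4)ccnc3c2)cc1`) gives 3470 nM, both beyond the scatter from compound 3. Compound 4 (`CC(C)(C)c1ccc(-c2ccc3c(NCCCNCc4ccco4)ccnc3c2)cc1`) keeps the tert-butyl of compound 3 but carries furan-2-yl in place of 2-hydroxy-3-methoxyphenyl on a saturated chain carbon bound to an amine nitrogen.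

Among the compounds with values here, no measured step changes that place alone. Within the data shown here, the one measured step, a 2.3-fold lower number from compound 1 to compound 3 (0.37 log units; beyond the scatter), is modest and concerns tert-butyl in place of methoxy on an aromatic carbon, so it bears on the group that compound 4 retains rather than on the change itself. Among the measured compounds shown here, compound 2 is the only measured compound with furan-2-yl, but it carries trifluoromethyl where compound 4 carries tert-butyl, so the gap between compound 3 and compound 2 mixes two structural differences. A move to a higher number in this assay is therefore expected, probably smaller than that whole gap, though the evidence is indirect. The expected change is a 2.5-fold higher number from compound 3 to compound 4 (0.39 log units; beyond the scatter). For compound 4 the estimated value is 1700 nM, with an expected range of 800 nM to 3600 nM.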

Compound 4, half-maximal effective concentration: 3150 nM
Estimate against measurement, compound 4: 1.9-fold (0.27 log units) below; low and high end bracket the measured number.
By their numbers in this assay, from the lowest: compound 3; then compounds 1, 4 and 2 (each within the scatter of the next, the first and the last beyond it).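

In this assay, within the data shown here, replacing 2-hydroxy-3-methoxyphenyl with furan-2-yl on a saturated chain carbon bound to an amine nitrogen, with tert-butyl kept in place, gives a 4.6-fold higher number from compound 3 to compound 4 (0.66 log units; beyond the scatter), the first measured step that changes this place alone and one larger than the earlier step on the aromatic carbon. With furan-2-yl kept in place, tert-butyl instead of trifluoromethyl gives a 1.1-fold lower number from compound 2 to compound 4 (0.04 log units; within the scatter), so this pair of groups on the aromatic carbon is not told apart in these two compounds, while the change at the chain carbon gives a step beyond the scatter. The data shown offer no measurement that accounts for the step at the chain carbon.

The compounds shown leave open whether the step follows the loss of the hydroxy group, the loss of the methoxy group or the change of ring, which an unsubstituted phenyl or a thiophen-2-yl at this place would help to separate. Also open, on these data alone, is whether the same change gives a step of similar size with methoxy in place of tert-butyl, and what a longer chain would do to these numbers.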